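Thioamide series: second chloro on the aniline ring

The compounds below may be only part of what the source reports. "The series", "measured", "known", "first", "only" and "open" are said of these compounds alone.

Of the compounds shown here, three have been measured in a functional assay on HepG2 cells (Homo sapiens) for cytotoxicity, with a stated time of 24 h; a lower number here means a stronger inhibitor, a higher number a weaker inhibitor. Compound 1 `COc1cc(Cl)ccc1C(=S)Nc1ccc(Cl)cc1O` gives 5110 nM. Compound 2 `COc1cc(Cl)ccc1C(=S)Nc1cc(Cl)c(Cl)cc1O`, which carries one more chloro group, gives 3160 nM; the change from compound 1 to compound 2 is chloro in place of hydrogen on an aromatic carbon, and it made a 1.6-fold lower number from compound 1 to compound 2 (0.21 log units; within the scatter). Compound 3 `COc1ccc(Cl)cc1C(=S)Nc1cc(Cl)ccc1O` gives 8600 nM in this assay; its core and the core of compound 1 are built from the same atoms joined differently, and the difference between the two cores is not broken down here. The values of compound 1 and compound 3 lie within the scatter of each other, while the values of compound 3 and compound 2 lie beyond it.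

Compound 4 `COc1ccc(Cl)cc1C(=S)Nc1cc(Cl)c(Cl)cc1O` has not yet been measured in this assay. It differs from compound 3 by chloro in place of hydrogen on an aromatic carbon. Within the data shown here, this is the same kind of change as the one from compound 1 to compound 2, but the surroundings differ: in compound 2 the entering chloro is meta to a large group and para to a hydroxy group, whereas in compound 4 it is meta to a hydroxy group and para to a large group. Among the measured compounds shown here, only one earlier instance of this change exists, so the expectation rests on it alone. The step expected from compound 3 to compound 4 is a 1.6-fold lower number from compound 3 to compound 4 (0.20 log units; within the scatter), sized on the step seen for compound 2 because it made a 1.6-fold lower number from compound 1 to compound 2 (0.21 log units; within the scatter). Compound 4 is therefore estimated at 5400 nM in this assay, with a range of 2500 nM to 11500 nM.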

Compound 4, half-maximal inhibitory concentration: 3720 nM
For compound 4 the middle estimate is 1.5-fold (0.16 log units) above the measured one; the range from low to high includes it.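

In this assay, chloro in place of hydrogen on an aromatic carbon gives a 2.3-fold lower number from compound 3 to compound 4 (0.36 log units; beyond the scatter), and this step can be set directly beside the earlier one on the other core: the same change on two cores in this assay, a 1.6-fold lower number (0.21 log units; within the scatter) from compound 1 to compound 2 and a 2.3-fold lower number (0.36 log units; beyond the scatter) from compound 3 to compound 4, 1.4-fold (0.16 log units) apart, within the scatter of two such steps

The two steps point the same way and do not differ beyond the scatter, even though only the newer step lies beyond the scatter by itself; as far as these two pairs go, the change carries from the core of compound 1 to the core of compound 3 with its direction kept and no measurable change in its size. Two pairs do not fix a general size for the step, however, and they show neither how the chloro group acts in these cells nor whether the same step would appear on any further core.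

Open among the compounds shown is whether another group entering at this same aromatic carbon, such as fluoro, methyl or an amine, would give a step of similar direction and size. Also open, as far as these compounds go, is how this assay would read with a carbonyl in place of the thiocarbonyl, or with a carboxylic acid in place of the hydroxy group, on either core.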